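Replacing the carbamoyl group of compound 1

This account rests on a few compounds, and the source may have more. Where it says the series, first, only, none or still open, it means among the compounds named here.

Compound 1 `CCCCCCCCCCCCNC(=O)[C@@H](N)CCC(N)=O`: 7940 nM
Compound 2 `CCCCCCCCCCCCNC(=O)C(N)CCN`: 1260 nM

Within the data shown here, in a functional assay on HL-60 cells (Homo sapiens) for activation (on this read-out lower numbers stand for an effect already at smaller amounts and higher numbers for an effect only at larger amounts of compound), compound 1 gives 7940 nM, the higher of the two numbers so far, while compound 2 gives 1260 nM. Compound 3 `CCCCCCCCCCCCNC(=O)[C@@H](N)CCCN=C(N)N` has not yet been measured. Its difference from compound 1 is this: a group of 5 heavy atoms (2 carbon, 3 nitrogen; no ring) in place of a group of 3 heavy atoms (1 carbon, 1 nitrogen, 1 oxygen; no ring), on a saturated chain carbon, three bonds along the chain from an amine nitrogen and a carbonyl carbon. The change lies on a saturated chain carbon, three bonds along the chain from an amine nitrogen and a carbonyl carbon.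

Among the measured compounds shown here, only one measured step bears on this change: a 6.3-fold lower number from compound 1 to compound 2 (0.80 log units; beyond the scatter). That step also removes the carbamoyl, but what enters there is not the group of 5 heavy atoms found in compound 3, so it is only a loose guide. For the measured compounds named here, no measurement yet shows the effect of this entering group. In this assay a step toward a lower number is therefore expected, of similar or somewhat smaller size, with a wide margin. The expected change is a 4.0-fold lower number from compound 1 to compound 3 (0.60 log units; beyond the scatter). For compound 3 the estimated value is 2000 nM, within an expected range from 500 nM to 7000 nM.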

Compound 3, half-maximal effective concentration: 794 nM
Compound 3: the middle estimate sits 2.5-fold (0.40 log units) above what was measured, within the range that was stated.
By their numbers in this assay, from the lowest: compounds 3 and 2 (each within the scatter of the next); then compound 1.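

In this assay, the earlier step showed the effect of only one replacement for the carbamoyl group. The new group of 5 heavy atoms, on a saturated chain carbon, three bonds along the chain from an amine nitrogen and a carbonyl carbon, gives a 10-fold lower number from compound 1 to compound 3 (1.00 log units; beyond the scatter), so a second, different replacement also moves the read-out toward a lower number. Compound 1 now stands apart from both replacements, while compound 3 at 794 nM and compound 2 at 1260 nM lie within the scatter of each other, so the two entering groups cannot be ranked in this read-out; no measurement at hand accounts for the step.

The compounds shown leave open how a carboxylic acid, a hydroxyl group or a methyl ester would read in place of the carbamoyl group, and whether a shorter or longer chain carrying the entering group of compound 3 would keep the lower number. With all values from this assay alone, they also leave open whether the step holds on any other read-out.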